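Swapping the benzyl amide substituent of compound 3

A few compounds are considered here, and "the series" means these few. Any claim that something is new, unique, unknown or untested is made for them only; others in the source may bear on it.

Compound 1 `Cc1ccc(CNC(=O)c2cccc(C(C)Oc3cccnc3Nc3ncccn3)c2)cc1` gives in a functional assay on NCI-H3122 cells (Homo sapiens) for antiproliferative activity, read by MTT assay, with a stated time of 48 h (on this read-out higher numbers stand for weaker inhibition and lower numbers for stronger inhibition), only the limit > 100000 nM. Compound 2 `Cc1ccc(CNC(=O)c2cccc(C(C)Oc3cccnc3Nn3cnnc3)c2)cc1` gives 23700 nM, and the step of an at least 4.2-fold lower number from compound 1 to compound 2 (0.62 log units; beyond the scatter) is the only measured step shown. Compound 3 `COc1cccc(CNC(=O)c2cccc(C(C)Oc3ccnc(Nc4cnn(C)c4)c3)c2)c1` also gives only a limit, > 100000 nM, so it sits with compound 1 at the limit of > 100000 nM in this assay, at which 2 of the 3 values shown sit. Going by the values given here, compound 4 `CC(Oc1ccnc(Nc2cnn(C)c2)c1)c1cccc(C(=O)NCc2cc(F)cc(F)c2)c1` differs from compound 3 by 3,5-difluorophenyl in place of 3-methoxyphenyl on a saturated chain carbon bound to an amide-type nitrogen, a change at the amide end of the molecule, not at the site of the step from compound 1 to compound 2; no measured step therefore bears on it, and the pair with compound 1 and compound 2 carries no lesson here. Compound 4 is expected to remain weak, with the expected step of an at least 1.2-fold lower number from compound 3 to compound 4 (0.09 log units; that floor lies within the scatter) within scatter, so compound 4 is estimated at 80000 nM, between 15000 nM and 400000 nM.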

Compound 4, half-maximal inhibitory concentration: 7600 nM
Compound 4: middle estimate off by 11-fold (1.02 log units), on the high side, outside the stated range (below it).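

The amide end of the molecule, untouched by the earlier step, clearly matters: in this assay, 3,5-difluorophenyl in place of 3-methoxyphenyl gives an at least 13-fold lower number from compound 3 to compound 4 (1.11 log units; beyond the scatter). Compound 3 gives only a limit, so this size is a floor, not an exact figure: the limit of > 100000 nM in this assay, at which 2 of the 4 values shown sit.

The compounds shown do not separate the effect of adding the two fluorines from that of removing the methoxy group. From the compounds shown here alone, whether 3-fluorobenzyl or 3,5-dichlorobenzyl would serve as well at this position remains open, as does whether 3,5-difluorobenzyl would bring a similar change on the core of compound 2.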